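Aryl Amide Variation on a Shared Core

The source may report more compounds than this note shows. Statements on the series, on what has been measured and on what is new or still open speak of the compounds shown alone.

Compound 2 `CN(C)C(=O)c1cc2cnc(Nc3ccc(NC(=O)C4(C(=O)Nc5cccc(Cl)c5)CC4)cc3)nc2n1C1CCCC1` and compound 1 `CN(C)C(=O)c1cc2cnc(Nc3ccc(NC(=O)C4(C(=O)Nc5ccc(F)cc5)CC4)cc3)nc2n1C1CCCC1` share one core and differ only in the aryl group carried on an amide-type nitrogen. For the measured compounds named here, in a functional assay on T47D cells (Homo sapiens) for inhibition, read by CCK-8 assay, with a stated time of 72 h, tested at 1 uM (a higher number here means more inhibition of growth at the concentration tested, a lower number less inhibition of growth), compound 1 gives 74.7%, while compound 2 gives 39.3%, the lower of the two numbers known here. Going by the values given here, the single measured step, a number 35.4 percentage points lower from compound 1 to compound 2 (beyond the scatter), shows that an exchange at this amide-type nitrogen can shift the read-out strongly. Compound 3 `CN(C)C(=O)c1cc2cnc(Nc3ccc(NC(=O)C4(C(=O)Nc5ccc(C(F)(F)F)cc5)CC4)cc3)nc2n1C1CCCC1` has not been measured; it differs from compound 2 in that (4-(trifluoromethyl)phenyl in place of 3-chlorophenyl on an amide-type nitrogen). Among the compounds with values here, this change resembles the measured step in that it again exchanges the aryl group at the same place, but no measured pair covers it directly, so its direction remains uncertain. Because compound 1 with its 4-fluorophenyl reached 74.7%, compound 3 is expected to show a step of a number 15.7 percentage points higher from compound 2 to compound 3 (beyond the scatter) in this assay, pointing upward. Compound 3 is therefore estimated at 55%, within 30% to 80%.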

Compound 3, percent growth inhibition at one concentration: 29.6%
The estimate for compound 3 lay 25.4 percentage points above the measured number, outside the stated range (below it).
By their numbers in this assay, from the lowest: compounds 3 and 2 (each within the scatter of the next); then compound 1.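

In this assay the exchange of 3-chlorophenyl for 4-(trifluoromethyl)phenyl on an amide-type nitrogen gives a number 9.7 percentage points lower from compound 2 to compound 3 (within the scatter), so this read-out does not separate these two aryl groups. Trifluoromethyl in place of fluoro on an aromatic carbon gives a number 45.1 percentage points lower from compound 1 to compound 3 (beyond the scatter), which shows that a single substituent on this aryl group can carry a large change and leaves compound 1 alone, with its 4-fluorophenyl, clear of the other two. Nothing given here accounts for this sensitivity.

The shown compounds leave open whether a small substituent in general is tolerated here or fluoro in particular, since only fluoro stands apart from the others. Going by these compounds, it also remains open how a methoxy group, an amine or a plain hydrogen in place of fluoro on that aromatic carbon would read in this assay.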